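Swapping carbamoyl for hydroxymethyl on a compound at the limit

The compounds below may be only part of what the source reports. "The series", "measured", "known", "first", "only" and "open" are said of these compounds alone.

Of the compounds shown here, two sharing one core have been tested so far, and neither gives a true number. Compound 1 `NC(=O)c1cn([C@H]2C[C@H](O)[C@@H](CO)O2)c(=O)[nH]c1=O` reads > 200000 nM in an ADME assay on CEM-SS cells (Homo sapiens) for cytotoxicity, read by MTT assay (on this read-out lower numbers stand for higher toxicity in this test and higher numbers for lower toxicity in this test), and this is a limit of the assay, not a measured value. Compound 2 `NC(=O)c1cn([C@H]2C[C@H](O)[C@@H](CO)O2)c(=O)nc1N` reads > 200000 nM in this assay and this too is only a limit. The whole picture so far is the limit of > 200000 nM in this assay, at which 2 of the 2 values shown sit, and no number separates the two compounds.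

Compound 3 `Nc1nc(=O)n([C@H]2C[C@H](O)[C@@H](CO)O2)cc1CO` differs from compound 2 by a single change hydroxymethyl in place of carbamoyl on an aromatic carbon with hydroxymethyl in place of carbamoyl on an aromatic carbon, ortho to an amino group. Going by the values given here, no measured step shows what such a swap does, so the only anchor is the limit of compound 2. No step beyond the usual scatter is expected in this assay in either direction. The estimated change is a number no higher from compound 2 to compound 3 (the limit leaves the size open) and it is expected to stay small. For compound 3 the estimated value is 200000 nM with an expected range from 100000 nM to 400000 nM and the assay may well report only a limit again.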

Compound 3, half-maximal cytotoxic concentration: > 200000 nM
Compound 3 ended at the assay's limit (the forecaster's own chance of this, stated with the estimate: 80%); the middle value lies on the limit itself.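

No step can be read from compound 2 to compound 3, because neither value is a true number: the limit of > 200000 nM in this assay, at which 3 of the 3 values shown sit.

The compounds shown leave open what hydroxymethyl in place of carbamoyl on an aromatic carbon does in this assay, and whether any true number separates compound 1, compound 2 and compound 3.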